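Adding a Methoxy Group to the Aryl Ring of Compound 1

A few compounds are considered here, and "the series" means these few. Any claim that something is new, unique, unknown or untested is made for them only; others in the source may bear on it.

Measured compounds:
compound 1, `CCOC(=O)[C@@H]1CC(=O)c2sccc2[C@H]1c1ccc(OC)cc1` — 18%
compound 2, `CCOC(=O)[C@@H]1CC(=O)c2sccc2[C@H]1c1ccc(OCC)cc1` — 19.8%

Of the compounds shown here, two sharing one core have been measured in a physicochemical assay, with a stated time of 60 min, tested at 40 ug/mL; on this read-out lower numbers stand for a weaker effect and higher numbers for a stronger effect at the one concentration tested. Compound 1 gives 18%. Compound 2 gives 19.8%. Going by the values given here, compound 1 holds the lowest of the two numbers, but its only neighbour is compound 2, and the step of a number 1.8 percentage points higher from compound 1 to compound 2 (within the scatter) lies within the scatter, so the two compounds cannot be placed in any order.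

Compound 3, `CCOC(=O)[C@@H]1CC(=O)c2sccc2[C@H]1c1ccc(OC)c(OC)c1`, has not been measured. It differs from compound 1 by methoxy in place of hydrogen on an aromatic carbon. Among the compounds with values here, the one measured step, a number 1.8 percentage points higher from compound 1 to compound 2 (within the scatter), changes the alkoxy group already present on that ring rather than adding a second one, so it bears on compound 3 only loosely; it showed no movement beyond the scatter. Nothing measured here speaks for a larger effect of a second methoxy group.

Compound 3 is therefore expected to give about 20%, somewhere between 8% and 32%. This estimate corresponds to an expected step of a number 2 percentage points higher from compound 1 to compound 3 (within the scatter), which is no change beyond the scatter.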

Compound 3, a percentage reported as activity, at one concentration (the size of the read-out at that concentration, not a potency): 16.6%
The estimate for compound 3 lay 3.4 percentage points above the measured number, and the stated range covers the measured number.
By their numbers in this assay, from the lowest: compounds 3, 1 and 2 (each within the scatter of the next).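

In this assay, the new methoxy group, on an aromatic carbon ortho to a methoxy group and meta to a large group, gives a number 1.4 percentage points lower from compound 1 to compound 3 (within the scatter). Going by these compounds alone, this is the first look at this aromatic carbon, since the earlier step, a number 1.8 percentage points higher from compound 1 to compound 2 (within the scatter), altered only the alkoxy group already on the ring, and compound 1 and compound 3 cannot be told apart on this read-out. Within these compounds, then, neither lengthening the existing alkoxy group nor adding a second methoxy group on this carbon gives a step beyond the scatter, and no available evidence offers an account of this result.

The compounds shown leave open whether a different kind of group on this same aromatic carbon, such as an amine or a carboxylic acid, would give a step beyond the scatter. They also leave open whether a longer chain on the oxygen at this carbon would do so, as a single methoxy group here says nothing about how the read-out would respond to larger alkoxy groups.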